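A few compounds are considered here, and "the series" means these few. Any claim that something is new, unique, unknown or untested is made for them only; others in the source may bear on it.

Of the compounds shown here, two have been measured so far. Compound 1 `Cc1ccc(S(=O)(=O)NC(=O)/C=C/c2ccc(F)cc2)cc1` carries a methyl on the aromatic ring attached to the sulfonyl group and a fluoro on the other ring; in a functional assay on B16-F10 cells (Mus musculus) for antiproliferative activity, read by ELISA and MTT assay, with a stated time of 48 h (a higher number here means a weaker inhibitor, a lower number a stronger inhibitor), compound 1 gives 4.8 ug/mL. Compound 2 `O=C(/C=C/c1ccc(F)cc1)NS(=O)(=O)c1ccc(Cl)cc1` differs from compound 1 only by a chloro in place of that methyl, and in this assay compound 2 gives 2.6 ug/mL. Among the compounds with values here, the step of a 1.8-fold lower number from compound 1 to compound 2 (0.27 log units; within the scatter) is the only measured step, and it lies within the scatter, so compound 1 and compound 2 cannot be told apart by this assay.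

Compound 3 `COc1ccc(/C=C/C(=O)NS(=O)(=O)c2ccc(C)cc2)cc1` is not yet measured. It differs from compound 1 as follows: methoxy in place of fluoro on an aromatic carbon. Within the data shown here, this change sits on the opposite ring from the one altered in the step from compound 1 to compound 2, so that step does not directly speak to it; it only shows that a small change on one aromatic ring left the number within the scatter. Among the measured compounds shown here, with no closer precedent, the expectation is for no step beyond the scatter, a 1.0-fold higher number from compound 1 to compound 3 (0.02 log units; within the scatter). For compound 3 in this assay the estimate is 5 ug/mL, with a range from 2.5 ug/mL to 10 ug/mL.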

Compound 3, half-maximal inhibitory concentration: 12.2 ug/mL
The estimate for compound 3 lay 2.4-fold (0.39 log units) below the measured number; measured number above the stated range.
By their numbers in this assay, from the lowest: compounds 2 and 1 (each within the scatter of the next); then compound 3.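

Exchanging fluoro for methoxy on an aromatic carbon para to a large group gives a 2.5-fold higher number from compound 1 to compound 3 (0.41 log units; beyond the scatter) in this assay, so compound 3 is the weaker inhibitor of this pair, though the step is modest. This is the first step shown to pass beyond the scatter, and it shows that this position on the fluoro-bearing ring is not indifferent to what sits there. The earlier step on the other ring, a 1.8-fold lower number from compound 1 to compound 2 (0.27 log units; within the scatter), could not show this, and one step on each ring is too little to rank the two rings against each other. No measurement available here explains why methoxy and fluoro differ at this position.

A single exchange cannot show whether the result would hold with chloro in place of the methyl, as in compound 2, on the other ring. It also leaves open how a hydroxy group, an amine, a bare hydrogen or a longer chain such as ethoxy would read at this position, so no trend can yet be drawn from fluoro and methoxy alone.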